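The step from compound 3 to compound 4

This account rests on a few compounds, and the source may have more. Where it says the series, first, only, none or still open, it means among the compounds named here.

Measured in a physicochemical assay for solubility, at pH 7.4; on this read-out lower numbers stand for lower solubility and higher numbers for higher solubility:
- Compound 1 `C[C@H](N)C(=O)N[C@@H]1CN(c2nc3c(cc2F)c(=O)c(C(=O)O)cn3C2CC2)[C@H]1C`: > 500 ug/mL, a limit
- Compound 2 `C[C@H](N)C(=O)N[C@@H](C)C(=O)N[C@@H]1CN(c2nc3c(cc2F)c(=O)c(C(=O)O)cn3C2CC2)[C@H]1C`: > 500 ug/mL, a limit
- Compound 3 `C[C@@H](N)C(=O)N[C@@H]1CN(c2nc3c(cc2F)c(=O)c(C(=O)O)cn3C2CC2)[C@H]1C`: 386 ug/mL

Among the measured compounds shown here, compound 3 holds the only true number of the three. Compound 4 `CC(C)C[C@H](N)C(=O)N[C@@H]1CN(c2nc3c(cc2F)c(=O)c(C(=O)O)cn3C2CC2)[C@H]1C` differs from it as follows: 1-amino-3-methylbutyl in place of 1-aminoethyl on a carbonyl carbon. For the measured compounds named here, two measured steps bear on this change. One is an at least 1.2-fold lower number from compound 2 to compound 3 (0.11 log units; that floor lies within the scatter), which also alters the group on a carbonyl carbon. The other is an at least 1.2-fold lower number from compound 1 to compound 3 (0.11 log units; that floor lies within the scatter), and it comes with the fact that compounds 1 and 3 differ only in the configuration as drawn. As far as these compounds go, both sizes stay open because of the limit of > 500 ug/mL in this assay, at which 2 of the 3 values shown sit. Neither floor lies beyond the scatter, so no step beyond the scatter is expected in this assay. The expected step is a 1.1-fold lower number from compound 3 to compound 4 (0.04 log units; within the scatter). For compound 4 the estimated value is 350 ug/mL, with an expected range from 150 ug/mL to 700 ug/mL.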

Compound 4, solubility: > 500 ug/mL
Compound 4 was reported as a limit; the forecaster's own chance of this, stated with the estimate: 30%; middle value at least 1.4-fold (0.15 log units) away from the limit.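

In this assay compound 4 gives > 500 ug/mL, which is a limit and not a number. Replacing 1-aminoethyl with 1-amino-3-methylbutyl on this carbonyl carbon gives an at least 1.2-fold higher number from compound 3 to compound 4 (0.11 log units; that floor lies within the scatter), so this position accepts the larger group without a drop to a readable number. The steps to compound 4 from compound 1 and compound 2 cannot be read, and the size of this step stays open because of: the limit of > 500 ug/mL in this assay, at which 3 of the 4 values shown sit.

As far as these compounds go, whether a longer chain or a phenyl group at this position would give a readable number remains open.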